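Trimming the Dihydroxypropyl Amide Back to a Methyl Amide

The source may hold more compounds than are shown below. What is called first, only, known or untested is meant among the compounds shown, and "the series" means these compounds.

Three compounds share one core and differ only in the group on a saturated chain carbon bound to a saturated ring carbon. Compound 1 `COCC[C@@H]1C[C@@H](c2ccc(Cl)c(Cl)c2)[C@H](NC(=O)c2cc(-c3c(Cl)cnn3C)c(Cl)o2)CN1` carries a methoxymethyl group there; in a functional assay on HCT-116 cells (Homo sapiens) for antiproliferative activity, read by sulforhodamine B assay, with a stated time of 72 h (on this read-out higher numbers stand for weaker inhibition and lower numbers for stronger inhibition), compound 1 gives 470 nM. Compound 2 `Cn1ncc(Cl)c1-c1cc(C(=O)N[C@@H]2CN[C@H](CC(N)=O)C[C@H]2c2ccc(Cl)c(Cl)c2)oc1Cl` carries a carbamoyl group instead, and in this assay compound 2 gives 650 nM, with a 1.4-fold higher number from compound 1 to compound 2 (0.14 log units; within the scatter). Compound 3 `Cn1ncc(Cl)c1-c1cc(C(=O)N[C@@H]2CN[C@H](CC(=O)NCC(O)CO)C[C@H]2c2ccc(Cl)c(Cl)c2)oc1Cl` carries a (2,3-dihydroxypropyl)carbamoyl group; in this assay compound 3 gives 7090 nM, the highest of the three numbers, with a 15-fold higher number from compound 1 to compound 3 (1.18 log units; beyond the scatter) and an 11-fold higher number from compound 2 to compound 3 (1.04 log units; beyond the scatter).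

Compound 4 `CNC(=O)C[C@@H]1C[C@@H](c2ccc(Cl)c(Cl)c2)[C@H](NC(=O)c2cc(-c3c(Cl)cnn3C)c(Cl)o2)CN1` is not yet measured. It differs from compound 3 in one place: hydrogen in place of 1,2-dihydroxyethyl on a saturated chain carbon bound to an amide-type nitrogen. This change largely undoes the step from compound 2 to compound 3, leaving only a methyl on the amide-type nitrogen. That step was large, an 11-fold higher number from compound 2 to compound 3 (1.04 log units; beyond the scatter), so the return is expected to be large as well, toward a lower number. Compound 4 is therefore expected to show a 7.9-fold lower number from compound 3 to compound 4 (0.90 log units; beyond the scatter). That would place it near compound 2 rather than compound 3. The estimate for compound 4 in this assay is 900 nM, with a range from 400 nM to 2500 nM.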

Compound 4, half-maximal inhibitory concentration: 450 nM
The estimate for compound 4 lay 2.0-fold (0.30 log units) above the measured number; the range from low to high includes it.
By their numbers in this assay, from the lowest: compounds 4, 1 and 2 (each within the scatter of the next); then compound 3.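

Cutting the 1,2-dihydroxyethyl portion away from the chain on the amide-type nitrogen gives a 16-fold lower number from compound 3 to compound 4 (1.20 log units; beyond the scatter) in this assay, so the weak result of compound 3 does not come from simply having a carbon group on that nitrogen. Within the data shown here, the step with methyl in place of hydrogen on the amide-type nitrogen, a 1.4-fold lower number from compound 2 to compound 4 (0.16 log units; within the scatter) and thus no measurable change, shows directly that this position accepts a methyl, which the earlier compounds could not show because none of them had so small a group there. Methylcarbamoyl in place of methoxymethyl on the saturated chain carbon bound to a saturated ring carbon gives a 1.0-fold lower number from compound 1 to compound 4 (0.02 log units; within the scatter) and so adds a third group that compound 1 and compound 2 cannot be told apart from in this read-out, while only compound 3 stands apart.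

On these data alone, it remains open where along the chain the loss begins, which an ethyl or 2-hydroxyethyl group on the amide nitrogen would help to show, and whether an amine or a carboxylic acid would be accepted in place of the amide. The data shown offer no measured explanation for the large loss in compound 3.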